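Methyl in Place of Isopropyl on the Fused Ring

A few compounds are considered here, and "the series" means these few. Any claim that something is new, unique, unknown or untested is made for them only; others in the source may bear on it.

Measured so far:
compound 1 `CCC1Nc2ccccc2C(=O)N1Cc1ccc(-c2ccccc2-c2nn[nH]n2)cc1`: 45000 nM
compound 2 `CCC1Nc2ccc(C(C)C)cc2C(=O)N1Cc1ccc(-c2ccccc2-c2nn[nH]n2)cc1`: 90 nM

Among the measured compounds shown here, compound 2 holds the lower of the two numbers in an assay on adrenal cortex for inhibition of angiotensinogen (Rattus norvegicus); a lower number here means a stronger inhibitor, a higher number a weaker inhibitor; the only other measured compound, compound 1, stands well above it. For the measured compounds named here, the single measured step, a 500-fold lower number from compound 1 to compound 2 (2.70 log units; beyond the scatter), shows how much the isopropyl group on the fused ring changed this assay.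

Compound 3 `CCC1Nc2ccc(C)cc2C(=O)N1Cc1ccc(-c2ccccc2-c2nn[nH]n2)cc1` differs from compound 2 by methyl in place of isopropyl on an aromatic carbon. The step from compound 1 to compound 2 bears directly on this change, since it installed the same isopropyl group on the same aromatic carbon and was large. Methyl keeps a smaller group at that carbon, so the number for compound 3 is expected to lie between those of compound 1 and compound 2, closer to compound 2, as a rise of a 5.6-fold higher number from compound 2 to compound 3 (0.74 log units; beyond the scatter). Compound 3 is therefore estimated at 500 nM, with a range from 100 nM to 3000 nM.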

Compound 3, half-maximal inhibitory concentration: 13000 nM
Estimate against measurement, compound 3: 26-fold (1.41 log units) below; the whole stated range lies below it.
By their numbers in this assay, from the lowest: compound 2; then compound 3; then compound 1.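

In this assay, methyl at this aromatic carbon gives only part of what isopropyl gives: a 3.5-fold lower number from compound 1 to compound 3 (0.54 log units; beyond the scatter) is a modest gain, while a 140-fold higher number from compound 2 to compound 3 (2.16 log units; beyond the scatter) is a large loss. The earlier pair showed only that a substituent here could matter, whereas this result shows that the gain depends strongly on which alkyl group is present and that a methyl group alone does not deliver most of it. Nothing available accounts for the gap between methyl and isopropyl.

The compounds shown leave open whether ethyl would fall nearer to methyl or to isopropyl, and whether tert-butyl or a longer chain would lower the number further. They also leave open whether a group containing oxygen or nitrogen at this carbon, such as methoxy or an amine, could match isopropyl.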